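A few compounds are considered here, and "the series" means these few. Any claim that something is new, unique, unknown or untested is made for them only; others in the source may bear on it.

Compound 1 `CC(C)[C@H](NC(=O)COc1cccc2ccccc12)C(=O)N[C@@H](CC(=O)O)C(=O)CSc1ncc[nH]1` — > 200000 nM
Compound 2 `CC(C)[C@H](NC(=O)COc1cccc2ccccc12)C(=O)N[C@@H](CC(=O)O)C(=O)CSc1nncn1C` — > 200000 nM
Compound 3 `CC(C)[C@H](NC(=O)COc1cccc2ccccc12)C(=O)N[C@@H](CC(=O)O)C(=O)COc1nc2ccccc2[nH]1` — > 200000 nM

All three compounds share one core and differ only in the group carried on the oxygen or sulfur of the side chain. In a functional assay on Jurkat cells (Homo sapiens) for inhibition (a lower number here means a stronger inhibitor, a higher number a weaker inhibitor), compound 1 gives > 200000 nM, which is a limit of the assay and not a number. In this assay compound 2 gives > 200000 nM, again a limit. Compound 3 gives > 200000 nM, also a limit. Compound 3 therefore stands exactly where the other two stand, at the limit of > 200000 nM in this assay, at which 3 of the 3 values shown sit.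

Compound 4 `CC(C)[C@H](NC(=O)COc1cccc2ccccc12)C(=O)N[C@@H](CC(=O)O)C(=O)COc1cncc2ccccc12` differs from compound 3 in one place: isoquinolin-4-yl in place of 1H-benzimidazol-2-yl on an oxygen on a saturated carbon. The measured steps that concern changing this end group are a step that the two limits leave unreadable from compound 1 to compound 2, a step that the two limits leave unreadable from compound 1 to compound 3 and a step that the two limits leave unreadable from compound 2 to compound 3. None of them can be read: every value sits at the limit. No direction or size of step can be derived from them, and the plain expectation is that compound 4 stays at the limit as well. Compound 4 is estimated at 200000 nM, within a range from 20000 nM to 1000000 nM. The expected step is a number no higher from compound 3 to compound 4 (the limit leaves the size open).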

Compound 4, half-maximal inhibitory concentration: 166000 nM
Beside the measured number, compound 4's estimate is 1.2-fold (0.08 log units) above it; measured number inside the range.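

In this assay, going by these compounds alone, compound 4 gives 166000 nM, the first real number rather than a limit of the assay. The other three compounds remain at a limit: the limit of > 200000 nM in this assay, at which 3 of the 4 values shown sit.

Measured against them, the change is an at least 1.2-fold lower number from compound 3 to compound 4 (0.08 log units; that floor lies within the scatter), an at least 1.2-fold lower number from compound 2 to compound 4 (0.08 log units; that floor lies within the scatter) and an at least 1.2-fold lower number from compound 1 to compound 4 (0.08 log units; that floor lies within the scatter), so isoquinolin-4-yl on this oxygen yields a readable value, but each step is only a floor, and the steps among compound 1, compound 2 and compound 3 cannot be read.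

The compounds shown leave open whether a phenyl or a pyridin-3-yl group on this same oxygen would give a lower number. They also leave open whether isoquinolin-4-yl carried on a sulfur instead of the oxygen would read the same.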